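Lengthening the chain on the ring nitrogen of compound 1

A few compounds are considered here, and "the series" means these few. Any claim that something is new, unique, unknown or untested is made for them only; others in the source may bear on it.

Compound 1 `Cn1nccc1-c1ccccc1NCC1=NCCN1` is one of three compounds tested in a functional assay with Alpha-1A adrenergic receptor (Homo sapiens) as the target, read by calcium flux; on this read-out higher numbers stand for larger maximal responses and lower numbers for smaller maximal responses. Compound 1 gives 108%, the second highest of the three numbers. Compound 2 `c1ccc(-c2nc[nH]n2)c(NCC2=NCCN2)c1` gives 135%, and the step of a number 27 percentage points higher from compound 1 to compound 2 (beyond the scatter) is a modest rise that comes from placing 1H-1,2,4-triazol-3-yl where 1-methyl-1H-pyrazol-5-yl stood. For the measured compounds named here, compound 3 `CCn1cc(-c2ccccc2NCC2=NCCN2)cn1` gives 0%, far beneath compound 1; no single-point step links compound 3 to compound 1, so only the two values themselves can be compared.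

Compound 4 `CCn1nccc1-c1ccccc1NCC1=NCCN1` differs from compound 1 by methyl in place of hydrogen on a saturated chain carbon bound to an aromatic nitrogen; cut one bond further out, the same difference reads methyl to ethyl. Going by the values given here, no measured step touches this position, so the step from compound 2 to compound 1 bears on it only as a sign that small changes here move the response modestly. A step of about the usual scatter, in either direction, is therefore expected for a number 13 percentage points lower from compound 1 to compound 4 (beyond the scatter). Compound 4 is estimated to give 95%, between 50% and 130%.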

Compound 4, largest response reached (reported as maximal response), in percent of the reference or control that the assay uses: 81%
Compound 4: the middle estimate sits 14 percentage points above what was measured; the measured number falls inside the stated range.
By their numbers in this assay, from the lowest: compound 3; then compound 4; then compound 1; then compound 2.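

In this assay, for the compounds shown here, this is the first direct reading of the chain on the ring nitrogen: methyl in place of hydrogen on a saturated chain carbon bound to an aromatic nitrogen produces a number 27 percentage points lower from compound 1 to compound 4 (beyond the scatter), so going from methyl to ethyl here changes the response by more than the scatter. The change lowers the maximal response without removing it, as compound 4 still gives 81%. Nothing shown here explains why the response falls.

One step cannot show whether the response keeps falling as the chain grows, and a longer chain such as propyl would test that. The compounds shown also leave open how a branched group such as isopropyl, or an ethyl chain ending in an amine, would behave at this place.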